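The compounds below may be only part of what the source reports. "The series", "measured", "known", "first", "only" and "open" are said of these compounds alone.

Measured in a functional assay on HCT-116 cells (Homo sapiens) for antiproliferative activity, read by CellTiter-Glo, with a stated time of 72 h; on this read-out lower numbers stand for stronger inhibition and higher numbers for weaker inhibition:
- compound 1 `O=C(NO)c1ccc(/C=C/c2ccnc(-c3ccccc3O)c2)cc1`: 1450 nM
- compound 2 `O=C(NO)c1ccc(/C=C/c2ccnc(-c3cccc(CO)c3)c2)cc1`: 1700 nM
- compound 3 `Cc1ccc(-c2cc(/C=C/c3ccc(C(=O)NO)cc3)ccn2)c(F)c1`: 800 nM

Compound 3 sits at the low end of these numbers. Against its nearest neighbour the difference is a 1.8-fold lower number from compound 1 to compound 3 (0.26 log units; within the scatter), and against the furthest it is a 2.1-fold lower number from compound 2 to compound 3 (0.33 log units; beyond the scatter).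

Compound 4 `O=C(NO)c1ccc(/C=C/c2ccnc(Br)c2)cc1` has not yet been measured. It carries bromo in place of 2-fluoro-4-methylphenyl on an aromatic carbon, next to the ring nitrogen (bromo in place of 2-fluoro-4-methylphenyl on an aromatic carbon).

The measured steps give only indirect guidance, since each swaps one substituted phenyl for another. They are small: a 1.2-fold higher number from compound 1 to compound 2 (0.07 log units; within the scatter), alongside the two already given. None shows what happens when the ring is lost altogether, so a wide range is needed. All three compounds that keep a ring fall close together, and compound 3 at 800 nM starts from the low end, so a modest move to a higher number is expected in this assay. The expected change is a 2.3-fold higher number from compound 3 to compound 4 (0.35 log units; beyond the scatter). For compound 4 the estimated value is 1800 nM, with an expected range of 600 nM to 5000 nM.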

Compound 4, half-maximal inhibitory concentration: > 10000 nM
Compound 4 gave a limit, no number (the forecaster's own chance of this, stated with the estimate: 5%); middle value at least 5.5-fold (0.74 log units) from the limit.
By their numbers in this assay, from the lowest: compounds 3, 1 and 2 (each within the scatter of the next, the first and the last beyond it). At a limit, above all of these: compound 4.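

In this assay the value of compound 4 is a limit and not a number: the limit of > 10000 nM in this assay, at which 1 of the 4 values shown sits. All three compounds that carry a substituted phenyl group stand well apart from it, with an at least 12-fold higher number from compound 3 to compound 4 (1.09 log units; beyond the scatter), an at least 5.8-fold higher number from compound 2 to compound 4 (0.76 log units; beyond the scatter) and an at least 6.8-fold higher number from compound 1 to compound 4 (0.83 log units; beyond the scatter). Swapping one substituted phenyl group for another at this position, next to the ring nitrogen, moved the number only in small steps, whereas bromo in place of the whole ring is a far larger change, which the earlier compounds could not show.

Going by these compounds, it remains open whether an aromatic ring is needed here at all, or whether a small group other than bromo, such as an amine or a short alkyl chain, would serve as well. On these data alone, how a phenyl group bearing a carboxylic acid would behave at this position also stays unknown.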